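Furan-2-yl to Phenyl Exchange on the Shared Core

A few compounds are considered here, and "the series" means these few. Any claim that something is new, unique, unknown or untested is made for them only; others in the source may bear on it.

Compound 1, `Oc1ccc(-c2cc(-c3ccccc3)nc(-c3ccccc3Cl)c2)cc1`, gives 4990 nM in a functional assay on HCT-15 cells (Homo sapiens) for cytotoxicity, read by CCK-8 assay and cell counting, with a stated time of 2 days; on this read-out lower numbers stand for stronger inhibition and higher numbers for weaker inhibition.
Compound 2, `Oc1ccc(-c2cc(-c3ccc(Cl)cc3)nc(-c3ccccn3)c2)cc1`, gives 21300 nM.
Compound 3, `Oc1ccc(-c2cc(-c3ccc(Cl)cc3)nc(-c3ccco3)c2)cc1`, gives 7020 nM.

Compound 3 stands second highest of the three numbers; compound 1 lies within the scatter of it, while compound 2 sits further off, a gap shown by a 3.0-fold lower number from compound 2 to compound 3 (0.48 log units; beyond the scatter). Compound 4, `Oc1ccc(-c2cc(-c3ccccc3)nc(-c3ccc(Cl)cc3)c2)cc1`, differs from compound 3 by phenyl in place of furan-2-yl on an aromatic carbon. For the measured compounds named here, no measured step exchanges furan-2-yl for phenyl, so the only guide is that compound 1, which also carries a phenyl group, gives a number close to that of compound 3. On that basis compound 4 is expected to stay near compound 3, with a step of a 1.3-fold lower number from compound 3 to compound 4 (0.11 log units; within the scatter) that would fall inside the scatter. The estimate for compound 4 is 5500 nM, within 2000 nM to 15000 nM.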

Compound 4, half-maximal inhibitory concentration: 6920 nM
Estimate against measurement, compound 4: 1.3-fold (0.10 log units) below, and the stated range covers the measured number.
By their numbers in this assay, from the lowest: compounds 1, 4 and 3 (each within the scatter of the next); then compound 2.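

In this assay, phenyl in place of furan-2-yl next to the ring nitrogen leaves no readable difference (a 1.0-fold lower number from compound 3 to compound 4 (0.01 log units; within the scatter)), so this position accepts either aromatic ring alike. Compound 2 stays apart, since phenyl in place of pyridin-2-yl gives a step beyond the scatter (a 3.1-fold lower number from compound 2 to compound 4 (0.49 log units; beyond the scatter)). Exchanging 2-chlorophenyl for 4-chlorophenyl also stays within the scatter (a 1.4-fold higher number from compound 1 to compound 4 (0.14 log units; within the scatter)).

Nothing available accounts for the pyridin-2-yl result. As far as these compounds go, whether an amine or a carboxylic acid on this carbon would shift the number remains open.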